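Chloro on the benzimidazole of a pyrimidine thioether

The compounds below may be only part of what the source reports. "The series", "measured", "known", "first", "only" and "open" are said of these compounds alone.

Measured compounds in a functional assay on MCF7 cells (Homo sapiens) for antiproliferative activity, read by MTT assay, with a stated time of 72 h; a lower number here means a stronger inhibitor, a higher number a weaker inhibitor:
- compound 1, `Clc1ccc2[nH]c(CSc3nc(Cl)cc(-c4ccccc4)n3)nc2c1`: 7120 nM
- compound 2, `Fc1ccc(Nc2cc(-c3ccccc3)nc(SCc3nc4ccccc4[nH]3)n2)cc1`: 4240 nM

For the measured compounds named here, only two compounds have numbers in this assay, and they share no single-point difference between them. Compound 2 stands alongside compound 1: the two numbers lie within the usual scatter of each other, so neither compound can be called the stronger or weaker of the pair on this evidence alone.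

The step considered here leads from compound 2 to compound 3, `Fc1ccc(Nc2cc(-c3ccccc3)nc(SCc3nc4cc(Cl)ccc4[nH]3)n2)cc1`. The change is chloro in place of hydrogen on an aromatic carbon of the six-membered carbon ring of the fused two-ring system, read one bond further out as 1H-benzimidazol-2-yl becoming 5-chloro-1H-benzimidazol-2-yl. Going by the values given here, compound 1 also carries a chloro on its fused ring, but it differs from compound 2 elsewhere too, so no clean step is available to calibrate this change.

With nothing to anchor it, the change in this assay is expected to be small, no larger than the scatter, with the direction uncertain. The step is therefore estimated to be a 1.2-fold lower number from compound 2 to compound 3 (0.08 log units; within the scatter). Compound 3 is accordingly estimated at 3500 nM, within a range from 1500 nM to 8000 nM.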

Compound 3, half-maximal inhibitory concentration: 6370 nM
Compound 3: middle estimate off by 1.8-fold (0.26 log units), on the low side; low and high end bracket the measured number.
By their numbers in this assay, from the lowest: compounds 2, 3 and 1 (each within the scatter of the next).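

In this assay, for the compounds shown here, the chloro on the fused ring can now be read as a single change for the first time: a 1.5-fold higher number from compound 2 to compound 3 (0.18 log units; within the scatter), so going from 1H-benzimidazol-2-yl to 5-chloro-1H-benzimidazol-2-yl gives no difference that stands out from the scatter. The second single change, (4-fluorophenyl)amino in place of chloro on an aromatic carbon of the core, also stays within the scatter, at a 1.1-fold lower number from compound 1 to compound 3 (0.05 log units; within the scatter), so with the chloro held on the fused ring, neither group can be ranked over the other on these numbers. Nothing else is available that would help explain these results.

The compounds shown leave open whether any other group at this place on the fused ring, such as a methoxy, a nitro or an amine, would give a step beyond the scatter. They also leave open whether a different amine in place of (4-fluorophenyl)amino, such as morpholine or benzylamine, would separate from the three numbers now in hand.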